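This account rests on a few compounds, and the source may have more. Where it says the series, first, only, none or still open, it means among the compounds named here.

Numbers in an assay on isolated protein for inhibition of DNA topoisomerase 1 (Homo sapiens), with a stated time of 30 min, tested at 100 uM; on this read-out lower numbers stand for a weaker effect and higher numbers for a stronger effect at the one concentration tested:
compound 1 `Oc1ccc(-c2cc(-c3ccc(Cl)cc3)nc(-c3ccsc3)c2)cc1` gives 47.7%
compound 2 `Oc1ccc(-c2cc(-c3ccc(Cl)cc3)nc(-c3ccccn3)c2)cc1` gives 12.7%
compound 3 `Oc1ccc(-c2cc(-c3ccc(Cl)cc3)nc(-c3ccco3)c2)cc1` gives 15.8%

Compound 3 stands second highest of the three; compound 2 lies within the scatter of it, and only compound 1 sits apart, a number 31.9 percentage points lower from compound 1 to compound 3 (beyond the scatter). Compound 4 `Oc1ccc(-c2cc(-c3ccncc3)nc(-c3ccc(Cl)cc3)c2)cc1` differs from compound 3 by pyridin-4-yl in place of furan-2-yl on an aromatic carbon. Going by the values given here, the steps that bear on this are a number 35 percentage points lower from compound 1 to compound 2 (beyond the scatter) and a number 31.9 percentage points lower from compound 1 to compound 3 (beyond the scatter), both large and both leading away from compound 1, and a number 3.1 percentage points higher from compound 2 to compound 3 (within the scatter), which is within the scatter: the compound carrying one five-membered aromatic ring with 1 hetero atom and the compound carrying one six-membered aromatic ring with 1 hetero atom at this position sit together. Since a six-membered aromatic ring with 1 nitrogen enters again, no step beyond the scatter is expected, a number 0.8 percentage points lower from compound 3 to compound 4 (within the scatter). Compound 4 is estimated at 15%, between 4% and 35%.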

Compound 4, a percentage reported as inhibition, at one concentration (the size of the read-out at that concentration, not a potency): 5.9%
For compound 4 the middle estimate is 9.1 percentage points above the measured one; the measured number falls inside the stated range.
By their numbers in this assay, from the lowest: compounds 4, 2 and 3 (each within the scatter of the next); then compound 1.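

At this position, on an aromatic carbon next to the ring nitrogen, pyridin-4-yl sits with furan-2-yl and pyridin-2-yl: the values fall a number 9.9 percentage points lower from compound 3 to compound 4 (within the scatter) and a number 6.8 percentage points lower from compound 2 to compound 4 (within the scatter), so changing pyridin-2-yl to pyridin-4-yl gives no readable shift. Thiophen-3-yl remains apart from all three, now also with a number 41.8 percentage points lower from compound 1 to compound 4 (beyond the scatter) as the step to pyridin-4-yl. Nothing at hand explains why thiophen-3-yl stands apart.

Open, as far as these compounds go, is whether the higher number belongs to thiophen-3-yl alone or would also appear with thiophen-2-yl, phenyl or a carboxylic acid here.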